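The source may hold more compounds than are shown below. What is called first, only, known or untested is meant among the compounds shown, and "the series" means these compounds.

Measured so far:
Compound 1, `Cc1cccc(NC(=O)c2coc3ccc(C)cc3c2=O)c1`: 17.1 nM
Compound 2, `COc1ccc2occ(C(=O)Nc3cccc(C)c3)c(=O)c2c1`: 21.8 nM

In an assay on cells for inhibition of Amine oxidase [flavin-containing] B (Homo sapiens), read by fluorescence and Amplex Red, using microsomes, with a stated time of 15 min (on this read-out higher numbers stand for weaker inhibition and lower numbers for stronger inhibition), compound 2 gives 21.8 nM, the higher of the two numbers recorded, while compound 1 gives 17.1 nM. Going by the values given here, the only step between measured compounds, a 1.3-fold higher number from compound 1 to compound 2 (0.11 log units; within the scatter), lies within the scatter, so on these two numbers the two compounds cannot be told apart.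

Compound 3, `COc1ccc2occ(C(=O)Nc3cccc(O)c3)c(=O)c2c1`, has not yet been measured. It differs from compound 2 by hydroxy in place of methyl on an aromatic carbon. Among the compounds with values here, no measured step carries the same change: the one step available, a 1.3-fold higher number from compound 1 to compound 2 (0.11 log units; within the scatter), concerns another place on the shared core and a different pair of groups, and it was itself within the scatter. It therefore offers no direct guide to the size or the direction of the coming step, and the expectation for compound 3 must rest on the closeness of the two measured numbers alone. The expected step is a 1.4-fold higher number from compound 2 to compound 3 (0.14 log units; within the scatter), with no firm direction and with wide uncertainty. Compound 3 is accordingly expected to give about 30 nM, with a range from 10 nM to 100 nM.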

Compound 3, half-maximal inhibitory concentration: 114 nM
Estimate against measurement, compound 3: 3.8-fold (0.58 log units) below, outside the stated range (above it).
By their numbers in this assay, from the lowest: compounds 1 and 2 (each within the scatter of the next); then compound 3.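

Going by these compounds alone, replacing 3-methylphenyl with 3-hydroxyphenyl gives a 5.2-fold higher number from compound 2 to compound 3 (0.72 log units; beyond the scatter) in this assay, and this is the first step that lies beyond the scatter. Within the data shown here, the position carrying this change on the aromatic ring of carbon only therefore responds to the group placed on it, moving here toward weaker inhibition, whereas the single earlier step, at another place on the shared core, could not separate its two compounds. Nothing measured alongside this result bears on why the hydroxy group gives the higher number, so the reason for the step remains unknown.

On these data alone, with only methyl and hydroxy compared at this position, it remains open whether the higher number follows from the hydrogen of the hydroxy group or from the loss of the methyl group, and a methoxy group or an amine in the same place would help separate these readings. As far as these compounds go, it also remains open whether the same exchange would give a step of similar size on the core of compound 1, which carries methyl rather than methoxy at the other varied place.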